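A few compounds are considered here, and "the series" means these few. Any claim that something is new, unique, unknown or untested is made for them only; others in the source may bear on it.

Working notes on the series.

The series shares one core, seen in compound 1 `COC(=O)C1=CN(C)C(=O)[C@@H]2C(CN3CCN(Cc4ccc(C(F)(F)F)cc4)CC3)=CC[C@H]12` and compound 2 `COC(=O)C1=CN(C(C)C)C(=O)[C@@H]2C(CN3CCN(Cc4cccc(C(F)(F)F)c4)CC3)=CC[C@H]12`. In a functional assay on Cortical neurone cells (Rattus norvegicus, strain Sprague-Dawley), read by MTT assay, with stated times of 24 h and 2 h, tested at 0.1 uM (on this read-out higher numbers stand for a stronger effect at the one concentration tested and lower numbers for a weaker effect), compound 1 gives 63%. In this assay compound 2 gives 58.7%, which stands within the scatter of the value of compound 1, the only other number shown, so the two values do not separate from each other on this read-out. Among the measured compounds shown here, no step between these two measured compounds can be isolated, as they differ in more than one place.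

Compound 3 `COC(=O)C1=CN(C)C(=O)[C@@H]2C(CN3CCN(Cc4cccc(C(F)(F)F)c4)CC3)=CC[C@H]12` is not yet measured in this assay. Compared with compound 2, the change is methyl in place of isopropyl on an amide-type nitrogen in a ring. Since the same methyl on the amide-type nitrogen is present in compound 1, whose value is 63%, and compound 2 with the isopropyl gives 58.7%, the expectation is that the step from compound 2 to compound 3 is small, a number 1.3 percentage points higher from compound 2 to compound 3 (within the scatter), with no direction beyond the scatter. For compound 3 the estimated value in this assay is 60%, in a range from 46% to 74%.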

Compound 3, a percentage reported as activity, at one concentration (the size of the read-out at that concentration, not a potency): 63.3%
Beside the measured number, compound 3's estimate is 3.3 percentage points below it; the measured number falls inside the stated range.
By their numbers in this assay, from the lowest: compounds 2, 1 and 3 (each within the scatter of the next).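

With compound 3, the amide-type nitrogen can be read on its own: in this assay, methyl in place of isopropyl gives a number 4.6 percentage points higher from compound 2 to compound 3 (within the scatter), so this read-out does not separate the two groups at this position when the 3-(trifluoromethyl)phenyl group is present. The same compound also isolates the aryl group, as 3-(trifluoromethyl)phenyl in place of 4-(trifluoromethyl)phenyl, with methyl on the amide-type nitrogen, gives a number 0.3 percentage points higher from compound 1 to compound 3 (within the scatter), and these two aryl groups do not separate at the one concentration tested either. Nothing available here bears on the reason for either result.

The compounds shown leave open whether a different group on the amide-type nitrogen, such as a hydrogen, a longer chain like n-butyl or a benzyl group, would give a number that stands clear of the scatter. They also leave open whether a nitrile or a methoxy group in place of the trifluoromethyl group would do so, and whether compounds that match at this single concentration would also match across a range of concentrations.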